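Removing the Fluorine from the Sulfonyl Aryl Ring

A few compounds are considered here, and "the series" means these few. Any claim that something is new, unique, unknown or untested is made for them only; others in the source may bear on it.

Three aryl sulfonamides built on one shared core have been measured in an assay on isolated protein for binding affinity to histamine H2 receptor (Homo sapiens); a higher number here means a weaker inhibitor, a lower number a stronger inhibitor. Compound 1 `O=C(c1ccc(OCCCN2CC[C@H](NS(=O)(=O)c3ccc(F)cc3)C2)cc1)C1CC1` gives 500 nM, compound 2 `N#Cc1ccc(S(=O)(=O)N[C@H]2CCN(CCCOc3ccc(C(=O)C4CC4)cc3)C2)cc1` gives 1600 nM, and compound 3 `O=C(c1ccc(OCCCN2CC[C@H](NS(=O)(=O)c3ccccc3F)C2)cc1)C1CC1` gives 1550 nM. Compound 3 therefore stands second highest of the three, level with compound 2 within the scatter, while the gap to the strongest member is a 3.1-fold higher number from compound 1 to compound 3 (0.49 log units; beyond the scatter). Compound 4 `O=C(c1ccc(OCCCN2CC[C@H](NS(=O)(=O)c3ccccc3)C2)cc1)C1CC1` differs from compound 3 by hydrogen in place of fluoro on an aromatic carbon. Among the measured compounds shown here, no measured step removes a substituent outright; the nearest comparisons are a 3.1-fold higher number from compound 1 to compound 3 (0.49 log units; beyond the scatter) and a 3.2-fold higher number from compound 1 to compound 2 (0.51 log units; beyond the scatter), both modest. A step of similar or smaller size, of uncertain direction, is expected, so compound 4 is estimated at 1000 nM (range 400 nM to 2500 nM), an expected step of a 1.6-fold lower number from compound 3 to compound 4 (0.19 log units; within the scatter).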

Compound 4, inhibition constant: 1200 nM
The estimate for compound 4 lay 1.2-fold (0.08 log units) below the measured number, within the range that was stated.
By their numbers in this assay, from the lowest: compound 1; then compounds 4, 3 and 2 (each within the scatter of the next).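

The phenyl group of compound 4 reads the same as 2-fluorophenyl in this assay with a 1.3-fold lower number from compound 3 to compound 4 (0.11 log units; within the scatter) here, so a fluoro ortho to a large group leaves no mark beyond the scatter. Cyano offers no separation from hydrogen either, with a 1.3-fold lower number from compound 2 to compound 4 (0.12 log units; within the scatter) as the step, whereas a 2.4-fold higher number from compound 1 to compound 4 (0.38 log units; beyond the scatter) leaves compound 1 alone apart from the unsubstituted compound. Nothing available gives a reason for this. As far as these compounds go, whether a chloro or a methoxy group on this ring would separate from hydrogen as the fluoro of compound 1 does remains open.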